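The compounds below may be only part of what the source reports. "The series", "measured", "known", "first", "only" and "open" are said of these compounds alone.

Values in an ADME assay on MT4 cells (Homo sapiens) for cytotoxicity, read by MTT assay; a higher number here means that more compound is tolerated, a lower number that less compound is tolerated:

- compound 1 `Cc1cccc(C(=O)N(C(=S)OCCN2C(=O)c3ccccc3C2=O)c2ccc(Cl)cc2)c1`: 58000 nM
- compound 2 `O=C1c2ccccc2C(=O)N1CCOC(=S)N(C(=O)c1cc(F)cc(F)c1)c1ccc(Cl)cc1`: 59000 nM
- compound 3 `O=C1c2ccccc2C(=O)N1CCOC(=S)N(C(=O)c1ccc(Cl)c([N+](=O)[O-])c1)c1ccc(Cl)cc1`: 48000 nM

The three values lie within the scatter of each other, so compound 3 is level with the other two. Compound 4 `Cc1cc(C(=O)N(C(=S)OCCN2C(=O)c3ccccc3C2=O)c2ccc(Cl)cc2)ccc1Br` has not yet been measured. It keeps the shared core and carries 4-bromo-3-methylphenyl in place of 4-chloro-3-nitrophenyl on a carbonyl carbon.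

Three measured steps changed this same place. They are a 1.0-fold higher number from compound 1 to compound 2 (0.01 log units; within the scatter), a 1.2-fold lower number from compound 1 to compound 3 (0.08 log units; within the scatter) and a 1.2-fold lower number from compound 2 to compound 3 (0.09 log units; within the scatter). The second of these is the closest guide, since it replaces the 3-methylphenyl of compound 1 with the group that compound 3 loses. For the measured compounds named here, no measured compound carries the bromine-bearing group, so the evidence is limited to three compounds. In this assay, no step beyond the scatter is expected in either direction. The estimated step is a 1.1-fold higher number from compound 3 to compound 4 (0.03 log units; within the scatter). The expected value for compound 4 is 52000 nM, with an estimated range from 28000 nM to 95000 nM.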

Compound 4, half-maximal cytotoxic concentration: 18000 nM
Compound 4: the middle estimate sits 2.9-fold (0.46 log units) above what was measured; measured number below the stated range.
By their numbers in this assay, from the lowest: compound 4; then compounds 3, 1 and 2 (each within the scatter of the next).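

In this assay the earlier changes on this carbonyl carbon had produced no step beyond the scatter, so the position had looked indifferent to the aromatic group it carries. The 4-bromo-3-methylphenyl group breaks that picture, with a 2.7-fold lower number from compound 3 to compound 4 (0.43 log units; beyond the scatter) and a 3.3-fold lower number from compound 2 to compound 4 (0.52 log units; beyond the scatter) showing that a change here can lower the concentration the cells tolerate. The clearest comparison is bromo in place of hydrogen on an aromatic carbon, which gives a 3.2-fold lower number from compound 1 to compound 4 (0.51 log units; beyond the scatter) and ties the step to the bromine within the context of the 3-methylphenyl group of compound 1.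

Going by these compounds, it remains open whether a plain 4-bromophenyl group without the methyl, or a 4-iodo or 4-amino group on the same ring, would give a similar step. No measurement shown here explains the step.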